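Bromobenzyl ethers: from 3-bromobenzyl to 2-bromobenzyl

This account rests on a few compounds, and the source may have more. Where it says the series, first, only, none or still open, it means among the compounds named here.

Measured so far in a functional assay on HepG2 cells (Homo sapiens) for antiproliferative activity, read by MTT assay, with a stated time of 24 h; on this read-out higher numbers stand for weaker inhibition and lower numbers for stronger inhibition:
- compound 1 `C#CCOc1ccc2c(=O)c(-c3cc(OC)c(OC)cc3OC)coc2c1` gives 4950 nM
- compound 2 `COc1cc(OC)c(-c2coc3cc(OCc4ccc(Br)cc4)ccc3c2=O)cc1OC` gives 1050 nM
- compound 3 `COc1cc(OC)c(-c2coc3cc(OCc4cccc(Br)c4)ccc3c2=O)cc1OC` gives 870 nM

Compound 3 sits level with compound 2, and both lie clearly under compound 1. Exchanging the ethynyl group for a bromophenyl group gave a 4.7-fold lower number from compound 1 to compound 2 (0.67 log units; beyond the scatter) and also a 5.7-fold lower number from compound 1 to compound 3 (0.76 log units; beyond the scatter). These two modest steps replace one group with a different one, so they say little about moving the bromine within the ring.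

The next compound is compound 4 `COc1cc(OC)c(-c2coc3cc(OCc4ccccc4Br)ccc3c2=O)cc1OC`, which carries 2-bromophenyl in place of 3-bromophenyl on a saturated chain carbon bound to an oxygen on an aromatic ring. For the measured compounds named here, the closest precedent is the other exchange between bromophenyl isomers, which gave a 1.2-fold lower number from compound 2 to compound 3 (0.08 log units; within the scatter). Going by the values given here, no compound with 2-bromophenyl has been measured yet, so that single small step is the only guide.

No step beyond the scatter is therefore expected in this assay, and no direction is favoured with confidence. The expected step is a 1.1-fold higher number from compound 3 to compound 4 (0.06 log units; within the scatter). The estimate for compound 4 is 1000 nM, with an expected range of 450 nM to 2200 nM.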

Compound 4, half-maximal inhibitory concentration: 2180 nM
Beside the measured number, compound 4's estimate is 2.2-fold (0.34 log units) below it; the measured number falls inside the stated range.
By their numbers in this assay, from the lowest: compounds 3 and 2 (each within the scatter of the next); then compound 4; then compound 1.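

In this assay, moving the bromine now registers: 2-bromophenyl in place of 3-bromophenyl gives a 2.5-fold higher number from compound 3 to compound 4 (0.40 log units; beyond the scatter), and 2-bromophenyl in place of 4-bromophenyl gives a 2.1-fold higher number from compound 2 to compound 4 (0.32 log units; beyond the scatter), whereas the exchange between the other two isomers stayed within the scatter. The bromine's ring position on this benzyl ether therefore matters for these three compounds, with 2-bromobenzyl standing apart and the 3-bromobenzyl and 4-bromobenzyl ethers level with each other. Part of the advantage over the ethynyl group survives in compound 4, with a 2.3-fold lower number from compound 1 to compound 4 (0.36 log units; beyond the scatter), so all three bromophenyl compounds remain under compound 1, though the 2-bromophenyl group keeps less of that advantage than the other two isomers. No available evidence accounts for the separation of the 2-bromophenyl compound from its two isomers.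

As far as these compounds go, whether the same order holds when bromine is replaced by fluorine, chlorine or a methoxy group on the benzyl ring remains open. Also open, from the compounds shown here alone, is whether a phenethyl ether, with its longer chain, or a benzyl ring carrying an amine or a carboxylic acid would fall with these ethers or apart from them.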